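Two limits and an ethynyl swap

A few compounds are considered here, and "the series" means these few. Any claim that something is new, unique, unknown or untested is made for them only; others in the source may bear on it.

- compound 1 `C#Cc1cn([C@@H]2O[C@H](CO)[C@@H](O)[C@H]2O)c2ncnc(NC)c12`: > 100000 nM
- compound 2 `CN(C)c1ncnc2c1c(-c1ccoc1)cn2[C@@H]1O[C@H](CO)[C@@H](O)[C@H]1O`: > 100000 nM

Both entries are limits of the assay, not numbers. Measured in an ADME assay on MRC5 cells (Homo sapiens), read by MTT assay, with a stated time of 72 h (on this read-out higher numbers stand for weaker inhibition and lower numbers for stronger inhibition), compound 2 stands at the limit of > 100000 nM in this assay, at which 2 of the 2 values shown sit. Going by the values given here, its exact value is therefore unknown, and no measured step shows how a structural change acts here. Compound 3 `C#Cc1cn([C@@H]2O[C@H](CO)[C@@H](O)[C@H]2O)c2ncnc(N(C)C)c12` differs from compound 2 by ethynyl in place of furan-3-yl on an aromatic carbon. With compound 1 and compound 2 both at the limit of > 100000 nM in this assay, at which 2 of the 2 values shown sit, no change beyond the scatter is expected in this assay. The expected a number no higher from compound 2 to compound 3 (the limit leaves the size open) is therefore close to nothing. Compound 3 is estimated at 100000 nM, within an expected range of 40000 nM to 200000 nM.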

Compound 3, half-maximal inhibitory concentration: 36100 nM
Compound 3: middle estimate off by 2.8-fold (0.44 log units), on the high side, and the stated range ends above it.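

In this assay, going by these compounds alone, compound 3 gives the first number that is not a limit, and this makes two steps readable. Ethynyl in place of furan-3-yl on this aromatic carbon gives an at least 2.7-fold lower number from compound 2 to compound 3 (0.44 log units; beyond the scatter), while methyl in place of hydrogen on the nitrogen on the aromatic ring gives an at least 2.7-fold lower number from compound 1 to compound 3 (0.44 log units; beyond the scatter). Both steps start from a limit, which leaves their true size open: the limit of > 100000 nM in this assay, at which 2 of the 3 values shown sit.

From the compounds shown here alone, whether a nitrile or a longer chain such as propynyl on the same aromatic carbon would change the number further remains open. Also open, going by these compounds, is whether the methyl step would hold with furan-3-yl on that carbon.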